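The source may hold more compounds than are shown below. What is called first, only, known or untested is meant among the compounds shown, and "the series" means these compounds.

Three compounds have so far been measured in an assay on membranes from brain for displacement of a labelled ligand from Sigma non-opioid intracellular receptor 1 (Cavia porcellus), read by scintillation counting, with a stated time of 120 min; a lower number here means a stronger inhibitor, a higher number a weaker inhibitor:

Compound 1 `c1ccc(CCCNC2CCc3ccsc3CC2)cc1` gives 187 nM.
Compound 2 `OCc1cc2c(s1)CCC(NCCCc1ccccc1)CC2` gives 61 nM.
Compound 3 `Brc1cc2c(s1)CCC(NCCCc1ccccc1)CC2` gives 41 nM.

Compound 3 has the lowest number of the three in this assay. Its gap to compound 2 is small, a 1.5-fold lower number from compound 2 to compound 3 (0.17 log units; within the scatter), so the two cannot be ordered on these numbers; its gap to compound 1 is clear, a 4.6-fold lower number from compound 1 to compound 3 (0.66 log units; beyond the scatter). Compound 4 `Oc1ccc(-c2cc3c(s2)CCC(NCCCc2ccccc2)CC3)cc1` is the next member of the series. Its change from compound 3 is 4-hydroxyphenyl in place of bromo on an aromatic carbon.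

For the measured compounds named here, two measured steps bear on this position: replacing hydrogen there with hydroxymethyl gave a 3.1-fold lower number from compound 1 to compound 2 (0.49 log units; beyond the scatter), and replacing hydrogen with bromo gave a 4.6-fold lower number from compound 1 to compound 3 (0.66 log units; beyond the scatter). Both substituents lowered the number by a modest amount, and the direct comparison between them, a 1.5-fold lower number from compound 2 to compound 3 (0.17 log units; within the scatter), lies within the scatter. So a group of either kind at this carbon has given a similar gain, and the data contain no example of a larger group such as 4-hydroxyphenyl. Compound 4 is therefore expected to stay close to compound 3 in this assay, with a step of a 1.3-fold lower number from compound 3 to compound 4 (0.11 log units; within the scatter), which is not expected to exceed the scatter. Compound 4 is estimated at 32 nM, in a range from 8 nM to 130 nM.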

Compound 4, inhibition constant: 181 nM
For compound 4 the middle estimate is 5.7-fold (0.75 log units) below the measured one; measured number above the stated range.
By their numbers in this assay, from the lowest: compounds 3 and 2 (each within the scatter of the next); then compounds 4 and 1 (each within the scatter of the next).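

In this assay, the aromatic carbon next to the ring sulfur turns out not to reward every group placed on it: 4-hydroxyphenyl, which brings seven heavy atoms and a six-membered aromatic ring of its own, gives a 4.4-fold higher number from compound 3 to compound 4 (0.64 log units; beyond the scatter) against bromo and a 3.0-fold higher number from compound 2 to compound 4 (0.47 log units; beyond the scatter) against hydroxymethyl. The gain that those two groups showed over hydrogen does not carry over to this group, since the step from the unsubstituted compound is a 1.0-fold lower number from compound 1 to compound 4 (0.01 log units; within the scatter), so this position accepts 4-hydroxyphenyl but shows no benefit from it over hydrogen. Nothing available here explains why this change moves the number as it does.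

The ring and the hydroxyl enter together in this single change, so the compounds shown cannot say which of them accounts for the step, and a plain phenyl or a 4-methoxyphenyl at this carbon would separate the two. They also leave open how groups of other kinds behave here, such as a short alkyl chain, an amine or a carboxylic acid, and whether any group goes beyond bromo at this position.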